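Replacing a thioether chain with a substituted cyclopropyl linker

The compounds below may be only part of what the source reports. "The series", "measured", "known", "first", "only" and "open" are said of these compounds alone.

Compound 1 `Cc1nc(NC2CC2)nc(N[C@@H]2C[C@H](C(C)(C)O)[C@@H](O)[C@H]2O)c1-c1nc2c(C)nccc2s1` and compound 2 `CSCCNc1nc(C)c(-c2nc3c(C)nccc3s2)c(N[C@@H]2C[C@H](C(C)(C)O)[C@@H](O)[C@H]2O)n1` share one core and differ only at a nitrogen on an aromatic ring. In an ADME assay on the whole organism (plasma) for pharmacokinetics, with Rattus norvegicus as the target, with a stated time of 6 h, at a dose of 10 mg/kg by the oral route (a lower number here means less compound in the circulation, a higher number more compound in the circulation at the dose given), compound 1 gives 27300 ng.h/mL, while compound 2 gives 807 ng.h/mL, the lowest of the two numbers measured; the change was a 34-fold lower number from compound 1 to compound 2 (1.53 log units; beyond the scatter). Compound 3 `COCC1(CNc2nc(C)c(-c3nc4c(C)nccc4s3)c(N[C@@H]3C[C@H](C(C)(C)O)[C@@H](O)[C@H]3O)n2)CC1` now takes the step (1-(methoxymethyl)cyclopropyl in place of (methylsulfanyl)methyl on a saturated chain carbon bound to a nitrogen on an aromatic ring). Among the measured compounds shown here, only one measured step bears on this change, and it shows that swapping a cyclopropyl for a flexible sulfur-bearing chain moved the number sharply downward. Compound 3 brings a three-membered carbon ring back, though held on a chain carbon and carrying a methoxymethyl group, so the author expects a partial recovery rather than a full return, estimated as a 3.1-fold higher number from compound 2 to compound 3 (0.49 log units; beyond the scatter) because the only reference is a 34-fold lower number from compound 1 to compound 2 (1.53 log units; beyond the scatter). Compound 3 is therefore estimated at 2500 ng.h/mL in this assay, with a range from 600 ng.h/mL to 10000 ng.h/mL.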

Compound 3, area under the concentration-time curve: 370 ng.h/mL
Compound 3: the middle estimate sits 6.8-fold (0.83 log units) above what was measured, and the stated range ends above it.
By their numbers in this assay, from the lowest: compound 3; then compound 2; then compound 1.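

In this assay, placing 1-(methoxymethyl)cyclopropyl in place of (methylsulfanyl)methyl on the saturated chain carbon gave a 2.2-fold lower number from compound 2 to compound 3 (0.34 log units; beyond the scatter) and so did not carry the number back toward that of compound 1. The larger group, set against the cyclopropyl of compound 1 held directly on the nitrogen, gave a 74-fold lower number from compound 1 to compound 3 (1.87 log units; beyond the scatter) and shows that among these compounds the return of a three-membered carbon ring did not by itself restore the high number. Nothing measured here accounts for either step.

The compounds shown leave open whether a plain cyclopropylmethyl on the nitrogen, without the methoxymethyl group, would stand nearer compound 1 or compound 3. They also leave open how a chain ending in an amine or a carboxylic acid would read in this assay at this place.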